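Swapping One Methoxy for Trifluoromethyl

The source may report more compounds than this note shows. Statements on the series, on what has been measured and on what is new or still open speak of the compounds shown alone.

Compound 1 `CN(Cc1cc(C(F)(F)F)cc(C(F)(F)F)c1)C(=O)c1c(OCCCC2CCN(C(=O)OC3(C)CC3)CC2)c2cccnc2n(C)c1=O` gives 47 nM in an assay on cells for inhibition of phosphatidylcholine:ceramide cholinephosphotransferase 2 (Homo sapiens), read by mass spectrometry, with stated times of 60 min and 30 min; on this read-out higher numbers stand for weaker inhibition and lower numbers for stronger inhibition.
Compound 2 `COc1cc(CN(C)C(=O)c2c(OCCCC3CCN(C(=O)OC4(C)CC4)CC3)c3cccnc3n(C)c2=O)cc(OC)c1` gives 300 nM in this assay.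

Of these two numbers, compound 2 has the higher one, and its gap to compound 1 lies beyond the usual scatter. Compound 3 `COc1cc(CN(C)C(=O)c2c(OCCCC3CCN(C(=O)OC4(C)CC4)CC3)c3cccnc3n(C)c2=O)cc(C(F)(F)F)c1` differs from compound 2 in one place: trifluoromethyl in place of methoxy on an aromatic carbon, on the six-membered aromatic ring of carbon only. Compound 3 is expected to move toward the lower number because compound 1 with two trifluoromethyl groups gives 47 nM. The expected step is a 2.7-fold lower number from compound 2 to compound 3 (0.44 log units; beyond the scatter). For compound 3 the estimate is 110 nM, within 50 nM to 250 nM.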

Compound 3, half-maximal inhibitory concentration in the phosphatidylcholine:ceramide cholinephosphotransferase 2 assay: 45 nM
Estimate against measurement, compound 3: 2.4-fold (0.39 log units) above, and the stated range ends above it.
By their numbers in the phosphatidylcholine:ceramide cholinephosphotransferase 2 assay, from the lowest: compounds 3 and 1 (each within the scatter of the next); then compound 2.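

In the phosphatidylcholine:ceramide cholinephosphotransferase 2 assay, a single trifluoromethyl group on this aromatic ring is enough: replacing one methoxy gives a 6.7-fold lower number from compound 2 to compound 3 (0.82 log units; beyond the scatter), while swapping the second trifluoromethyl for methoxy gives a 1.0-fold lower number from compound 1 to compound 3 (0.02 log units; within the scatter), so a second trifluoromethyl group shows no gain here. That gain in inhibition comes with a cost in a physicochemical assay for solubility, read by LC-MS, at pH 6.8 (a higher number here means a more soluble compound, a lower number a less soluble compound), where compound 2 gives 16 ug/mL and compound 3 gives 0.79 ug/mL: the measured solubility of compound 2, 16 ug/mL, and of compound 3, 0.79 ug/mL, a 20-fold lower number (1.31 log units; beyond the scatter)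

Still open, on these data alone, is whether another group at this place, such as chlorine or a nitrile, would keep the low number in the phosphatidylcholine:ceramide cholinephosphotransferase 2 assay while giving a higher number in the physicochemical assay.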